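This account rests on a few compounds, and the source may have more. Where it says the series, first, only, none or still open, it means among the compounds named here.

Measured compounds:

Compound 1 `COc1ccc(/C=C/C(=O)c2sc(Nc3ccc(Cl)cc3)nc2C)cc1` — in a functional assay on NCI-H460 cells (Homo sapiens) for cytotoxicity, read by MTT assay (on this read-out higher numbers stand for weaker inhibition and lower numbers for stronger inhibition), compound 1 gives > 25000 nM, which is a limit of the assay and not a number.
Compound 2 `Cc1nc(Nc2ccccc2)sc1C(=O)/C=C/c1ccc(Cl)cc1` — compound 2 gives > 25000 nM, again a limit.
Compound 3 `Cc1ccccc1Nc1nc(C)c(C(=O)/C=C/c2ccc(Cl)cc2)s1` — compound 3 gives > 25000 nM, also a limit.

Compound 3 thus stands at the limit of this assay, as do the other two values shown; all sit at the limit of > 25000 nM in this assay, at which 3 of the 3 values shown sit. Going by the values given here, the only measured step that touches compound 3 is a step that the two limits leave unreadable from compound 2 to compound 3, and with both ends at the limit its size cannot be read.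

The next compound, compound 4 `Cc1ccc(Nc2nc(C)c(C(=O)/C=C/c3ccc(Cl)cc3)s2)cc1`, differs from compound 3 by 4-methylphenyl in place of 2-methylphenyl on a nitrogen on an aromatic ring. Among the compounds with values here, no readable step bears on this change: the one neighbouring step is unreadable, and every value is a limit. There is therefore no basis for expecting a step of any size in either direction; the most that can be said is that the series has so far given nothing but limits.

Compound 4 is accordingly expected to sit at 40000 nM, with a range from 15000 nM to 100000 nM. That expectation means an estimated step that the limit leaves unreadable from compound 3 to compound 4, most likely reported again only as a limit.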

Compound 4, half-maximal inhibitory concentration: > 25000 nM
Compound 4: no number, only a limit; the forecaster's own chance of this, stated with the estimate: 85%; the middle value does not contradict the limit.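

In this assay compound 4 gives > 25000 nM, a limit and not a number. Going by these compounds alone, no step from compound 2 or compound 3 to compound 4 can be read. The compounds shown leave open whether 2-methylphenyl and 4-methylphenyl differ at all, and how far any compound lies past the shared limit: the limit of > 25000 nM in this assay, at which 4 of the 4 values shown sit.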